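The source may report more compounds than this note shows. Statements on the series, on what has been measured and on what is new or still open speak of the compounds shown alone.

Compound 1 `CN(C)CCC(OC(=O)Nc1ccc(C(F)(F)F)cc1)c1ccc(Cl)cc1` was tested in an assay on NIH3T3 cells with Urotensin-2 receptor (Homo sapiens) as the target (a lower number here means that less compound is needed, a higher number that more compound is needed for the effect), and in this assay compound 1 gives 251 nM. Compound 2 `CN(C)CCC(OC(=O)Nc1ccc(-c2ccccc2)cc1)c1ccc(Cl)cc1` differs from compound 1 by one change, (phenyl in place of trifluoromethyl on an aromatic carbon), and in this assay compound 2 gives 269 nM, so the step of a 1.1-fold higher number from compound 1 to compound 2 (0.03 log units; within the scatter) stays within the scatter. Compound 3 `CN(C)CCC(NC(=O)Nc1ccc(C(F)(F)F)cc1)c1ccc(Cl)cc1` rests on a different core; the difference between the two cores is not broken down here. In this assay compound 3 gives 117 nM, the lowest of the three numbers, and its gaps to compound 1 and to compound 2 both lie beyond the scatter. Compound 4 `CN(C)CCC(NC(=O)Nc1ccc(-c2ccccc2)cc1)c1ccc(Cl)cc1` has not yet been measured; it differs from compound 3 by the same change seen before, (phenyl in place of trifluoromethyl on an aromatic carbon), at the same place. Because the earlier step of a 1.1-fold higher number from compound 1 to compound 2 (0.03 log units; within the scatter) lay within the scatter, the expected step from compound 3 to compound 4 is a 1.1-fold higher number from compound 3 to compound 4 (0.03 log units; within the scatter), also within the scatter. Compound 4 is therefore estimated at 125 nM in this assay, with a likely range from 60 nM to 260 nM.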

Compound 4, half-maximal effective concentration: 145 nM
Compound 4: the middle estimate sits 1.2-fold (0.06 log units) below what was measured, and the stated range covers the measured number.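

In this assay, phenyl in place of trifluoromethyl on an aromatic carbon gives a 1.2-fold higher number from compound 3 to compound 4 (0.09 log units; within the scatter), and the change behaves alike on the two cores: the same change on two cores in this assay, a 1.1-fold higher number (0.03 log units; within the scatter) from compound 1 to compound 2 and a 1.2-fold higher number (0.09 log units; within the scatter) from compound 3 to compound 4, 1.2-fold (0.06 log units) apart, within the scatter of two such steps. A swap that stays within the scatter on the core of compound 1 thus also stays within it on the core of compound 3, so for this pair of groups the small step carries over from one core to the other. Going by these compounds alone, this rests on only two pairs, however, and it does not show that the change would stay as small on any further core, nor does it show that a change with a larger step would carry over equally well.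

The compounds shown leave open whether another group at the same place, such as a methoxy, a nitrile or a carboxylic acid, would move the number beyond the scatter on either core. They also leave open what a primary amine or a longer chain would do in place of the dimethylamino end.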